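Bromo removal on the indole acid in two hydrazone cores

The source may report more compounds than this note shows. Statements on the series, on what has been measured and on what is new or still open speak of the compounds shown alone.

Measured so far:
compound 1 `COc1ccc2c(c1)c(/C=N\NC(=O)c1c[nH]c3ccc(Br)cc13)cn2Cc1ccc(Cl)cc1` — 5000 nM
compound 2 `COc1ccc2c(c1)c(/C=N\NC(=O)c1c[nH]c3ccccc13)cn2Cc1ccc(Cl)cc1` — 82700 nM
compound 3 `COc1ccc(Cn2cc(/C=N\NC(=O)c3c[nH]c4ccc(Br)cc34)c3ccc(F)cc32)cc1` — 99800 nM

In a functional assay on MDA-MB-231 cells (Homo sapiens) for cytotoxicity (on this read-out higher numbers stand for weaker inhibition and lower numbers for stronger inhibition), compound 1 gives 5000 nM. The change hydrogen in place of bromo on an aromatic carbon produced a 17-fold higher number from compound 1 to compound 2 (1.22 log units; beyond the scatter), so compound 2 gives 82700 nM. Compound 3 gives 99800 nM; the difference between the core of compound 3 and the core of compound 1 is not broken down here, and the two values of compound 2 and compound 3 lie within the scatter of each other.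

Compound 4 `COc1ccc(Cn2cc(/C=N\NC(=O)c3c[nH]c4ccccc34)c3ccc(F)cc32)cc1` is not yet measured. It differs from compound 3 by hydrogen in place of bromo on an aromatic carbon, the same change seen from compound 1 to compound 2. With compound 3 already standing at 99800 nM, a further weakening of similar size is expected to carry compound 4 to a still higher number. The step of a 2.5-fold higher number from compound 3 to compound 4 (0.40 log units; beyond the scatter) is expected for compound 4 because a 17-fold higher number from compound 1 to compound 2 (1.22 log units; beyond the scatter) was seen for the same change. Compound 4 is thus estimated at 250000 nM in this assay, expected between 100000 nM and 800000 nM.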

Compound 4, half-maximal inhibitory concentration: 71200 nM
Compound 4: middle estimate off by 3.5-fold (0.55 log units), on the high side; the whole stated range lies above it.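

In this assay, hydrogen in place of bromo on the core of compound 3 gives a 1.4-fold lower number from compound 3 to compound 4 (0.15 log units; within the scatter), so the large step seen on the core of compound 1 does not recur there. The two steps do not agree, and the gap between them is larger than the scatter of two such steps allows: the same change on two cores in this assay, a 17-fold higher number (1.22 log units; beyond the scatter) from compound 1 to compound 2 and a 1.4-fold lower number (0.15 log units; within the scatter) from compound 3 to compound 4, 23-fold (1.37 log units) apart, beyond the scatter of two such steps. This shows that the result of removing the bromo cannot be carried from the core of compound 1 to the core of compound 3, but it rests on a single pair per core, and as the two cores differ in more than one place, it does not show which difference separates the two outcomes or why.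

As far as these compounds go, it remains open which of the parts that differ between the two cores decides whether the 5-bromo-1H-indol-3-yl group outperforms the 1H-indol-3-yl group. Also open, from the compounds shown here alone, is how a nitrile or a trifluoromethyl group in place of the bromo would read on either core.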